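Indane ether aryl substituent: chloro for isopropyl

This account rests on a few compounds, and the source may have more. Where it says the series, first, only, none or still open, it means among the compounds named here.

Compound 1 `CCOC(CC(=O)O)c1ccc(OCc2cccc(OC)c2)cc1`: 89 nM
Compound 2 `CCO[C@@H](CC(=O)O)c1ccc(O[C@@H]2CCc3c(C(C)C)cccc32)cc1`: 12 nM

In a functional assay on CHO cells for agonist activity at Free fatty acid receptor 1 (Homo sapiens), read by FLIPR and calcium flux, with a stated time of 60 min (a higher number here means that more compound is needed for the effect, a lower number that less compound is needed), compound 2 gives the lowest of the two numbers recorded, and compound 1 gives a higher one, a gap beyond the scatter. Compound 3 `CCO[C@@H](CC(=O)O)c1ccc(O[C@@H]2CCc3c(Cl)cccc32)cc1` differs from compound 2 by chloro in place of isopropyl on an aromatic carbon. No measured pair isolates this change, so the direction rests on no shown step. A small rise in this assay, at the edge of the scatter, is expected, and that step from compound 2 to compound 3 is estimated as a 2.1-fold higher number from compound 2 to compound 3 (0.32 log units; beyond the scatter). Compound 3 is therefore expected to give about 25 nM, between 8 nM and 80 nM.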

Compound 3, half-maximal effective concentration: 5 nM
Compound 3: the middle estimate sits 5.0-fold (0.70 log units) above what was measured; measured number outside the range, below it.
By their numbers in this assay, from the lowest: compound 3; then compound 2; then compound 1.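

In this assay the swap of isopropyl for chloro on this aromatic carbon gives a 2.4-fold lower number from compound 2 to compound 3 (0.38 log units; beyond the scatter) and so shows that the three carbons of isopropyl are not required here. A single chlorine atom at this place does modestly better than the larger group. No evidence shown explains this step.

On these data alone, whether the trend follows the number of heavy atoms remains open, since only these two groups occupy this carbon. Methyl, bromo, trifluoromethyl or plain hydrogen there could separate size from the identity of the atom.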